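Returning a Dihalophenyl Where the Trimethoxyphenyl Stood

The compounds below may be only part of what the source reports. "The series", "measured", "known", "first", "only" and "open" are said of these compounds alone.

Compound 3 `COc1ccc(/C=N/NC(=O)Nc2ccc(Oc3ccnc(-c4nncn4CCN(C)C)c3)c(F)c2)c(OC)c1OC` stands highest of the three measured compounds in a functional assay on NCI-H460 cells (Homo sapiens) for cytotoxicity, read by MTT assay, with a stated time of 72 h (a lower number here means a stronger inhibitor, a higher number a weaker inhibitor), at 1790 nM. Compound 1 `CN(C)CCn1cnnc1-c1cc(Oc2ccc(NC(=O)N/N=C/c3ccc(Cl)cc3Cl)cc2F)ccn1` gives 130 nM in this assay, and compound 2 `CN(C)CCn1cnnc1-c1cc(Oc2ccc(NC(=O)N/N=C/c3cc(C(C)(C)C)cc(C(C)(C)C)c3O)cc2F)ccn1` gives 590 nM. For the measured compounds named here, the one single-point step among them is a 14-fold higher number from compound 1 to compound 3 (1.14 log units; beyond the scatter), a large rise. Compound 4 `CN(C)CCn1cnnc1-c1cc(Oc2ccc(NC(=O)N/N=C/c3ccc(F)cc3F)cc2F)ccn1` differs from compound 3 by 2,4-difluorophenyl in place of 2,3,4-trimethoxyphenyl on a carbon with a double bond to nitrogen. As far as these compounds go, this change largely reverses that measured step: a dihalophenyl returns where the 2,4-dichlorophenyl of compound 1 had given 130 nM, so a lowering step of comparable size is expected for compound 4, with some caution since fluorine in place of chlorine is untested here. Compound 4 is therefore estimated at 200 nM in this assay, within 70 nM to 600 nM, which is an expected step of a 9.0-fold lower number from compound 3 to compound 4 (0.95 log units; beyond the scatter).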

Compound 4, half-maximal inhibitory concentration: 1930 nM
Estimate against measurement, compound 4: 9.7-fold (0.98 log units) below, outside the stated range (above it).
By their numbers in this assay, from the lowest: compound 1; then compound 2; then compounds 3 and 4 (each within the scatter of the next).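

In this assay, 2,4-difluorophenyl and 2,3,4-trimethoxyphenyl on this carbon with a double bond to nitrogen cannot be told apart, with a 1.1-fold higher number from compound 3 to compound 4 (0.03 log units; within the scatter). A dihalophenyl group alone therefore does not secure the low number of compound 1: 2,4-difluorophenyl in place of 2,4-dichlorophenyl gives a 15-fold higher number from compound 1 to compound 4 (1.17 log units; beyond the scatter), so the exchange of fluorine for chlorine is itself a large change here. Nothing shown accounts for this gap between the two dihalophenyl groups. As far as these compounds go, whether both chlorines are needed remains open, and 4-chlorophenyl or 2,4-dibromophenyl at this carbon could test this.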